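From Methoxy to Propoxy on the Shared Core

The compounds below may be only part of what the source reports. "The series", "measured", "known", "first", "only" and "open" are said of these compounds alone.

In a functional assay on HL-60 cells (Homo sapiens) for cytotoxicity (a lower number here means a stronger inhibitor, a higher number a weaker inhibitor), compound 2 `CO[C@H]1C=C(COC(C)=O)C(=O)[C@H](O)[C@H]1O` gives > 50000 nM, which is a limit and not a number. Compound 1 `CC(=O)OCC1=C[C@H](OCc2ccc3ccccc3c2)[C@H](O)[C@@H](O)C1=O` gives > 50000 nM, also a limit. Within the data shown here, compound 2 therefore stands at the limit, and so does the only other measured compound: the limit of > 50000 nM in this assay, at which 2 of the 2 values shown sit. Among the measured compounds shown here, the two measured compounds differ in more than one place, so they offer no measured step to guide the next change.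

Compound 3 `CCCO[C@H]1C=C(COC(C)=O)C(=O)[C@H](O)[C@H]1O` takes compound 2 from methoxy to propoxy, with ethyl in place of hydrogen on a saturated chain carbon bound to an oxygen on a saturated carbon. With compound 2 at > 50000 nM, a limit, no step beyond the scatter is expected in this assay. The expected step is a step that the limit leaves unreadable from compound 2 to compound 3. Compound 3 is estimated at 60000 nM, with an expected range from 25000 nM to 100000 nM.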

Compound 3, half-maximal inhibitory concentration: 10100 nM
Compound 3: the middle estimate sits 5.9-fold (0.77 log units) above what was measured; measured number below the stated range.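

In this assay, the change from methoxy to propoxy gives an at least 4.9-fold lower number from compound 2 to compound 3 (0.69 log units; beyond the scatter), so this position, a saturated chain carbon bound to an oxygen on a saturated carbon, can move the read-out on the shared core. Compound 3 is the only one of the three compounds shown with a measured number rather than a limit, and it gives the first readable step. The true size of that step remains unknown, because compound 2 has only a limit as its value: the limit of > 50000 nM in this assay, at which 2 of the 3 values shown sit.

What the change does in the cells, and why ethyl in place of hydrogen has this result, remains open. On these data alone, it is also open whether ethoxy, a longer chain such as hexyloxy, or an amine at the end of the chain would carry the number further.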